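The source may report more compounds than this note shows. Statements on the series, on what has been measured and on what is new or still open speak of the compounds shown alone.

Measured compounds in this assay:
compound 1 `CCNC1=Nc2ccc(Cl)cc2C(C)(C)C1`: 85.1%
compound 2 `CN(C)CCNC1=Nc2ccc(Cl)cc2C(C)(C)C1`: 50.8%
compound 3 `CN(C)CCCNC1=Nc2cccc(Cl)c2C(C)(C)C1`: 43.9%

In a functional assay on MDA-MB-231 cells (Homo sapiens) for cytotoxicity, read by MTT assay, with a stated time of 72 h, tested at 5 uM, in the absence of a further agent (a lower number here means a stronger effect, a higher number a weaker effect of the compound at the concentration tested), compound 1 stands highest of the three numbers, meaning the weakest effect; the step of a number 34.3 percentage points lower from compound 1 to compound 2 (beyond the scatter) is large, and compound 3 lies further below still. Compound 4 `CC1(C)CC(NCCCO)=Nc2ccc(Cl)cc21` differs from compound 1 by hydroxymethyl in place of hydrogen on a saturated chain carbon, two bonds along the chain from an amine nitrogen. Going by the values given here, the one measured step at this very place, a number 34.3 percentage points lower from compound 1 to compound 2 (beyond the scatter), brought in a different group, dimethylamino, and no step with hydroxymethyl has been measured, so its bearing is only indirect. A drop beyond the scatter is therefore expected, but a smaller one than with dimethylamino: for compound 4 the expected step is a number 15.1 percentage points lower from compound 1 to compound 4 (beyond the scatter). The estimate for compound 4 is 70%, between 50% and 90%.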

Compound 4, a percentage reported as activity, at one concentration (the size of the read-out at that concentration, not a potency): 84.2%
For compound 4 the middle estimate is 14.2 percentage points below the measured one; the range from low to high includes it.
By their numbers in this assay, from the lowest: compounds 3 and 2 (each within the scatter of the next); then compounds 4 and 1 (each within the scatter of the next).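

In this assay, putting hydroxymethyl on this chain carbon in place of hydrogen gives a number 0.9 percentage points lower from compound 1 to compound 4 (within the scatter), so not every group placed here goes with a lower number. Set against dimethylamino at the same place, hydroxymethyl gives a number 33.4 percentage points higher from compound 2 to compound 4 (beyond the scatter), which shows that the result at this place depends on which group enters. No evidence at hand says why these two groups differ. Going by these compounds, it remains open whether a primary amine, a carboxylic acid or a longer chain at this place would give a number closer to that of compound 2 or that of compound 4.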